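The source may hold more compounds than are shown below. What is called first, only, known or untested is meant among the compounds shown, and "the series" means these compounds.

Measured compounds:
`O=C(O)c1cnn(Cc2cc(Br)ccc2OCc2ccccc2)c1` compound 1, in a functional assay on CHO-K1 cells for antagonist activity at prostaglandin E2 receptor EP1 subtype (Homo sapiens), read by FLIPR (on this read-out higher numbers stand for weaker inhibition and lower numbers for stronger inhibition), compound 1 gives < 2000 nM
`COc1ccccc1COc1ccc(Br)cc1Cn1nc(C(=O)O)cc1C` compound 2, in this assay compound 2 gives 69.2 nM

The value of compound 1 is a limit of this assay, not a number; (the limit of < 2000 nM in this assay, at which 1 of the 2 values shown sits). Compound 2 carries the only number shown in this assay, so it stands alone. Compound 3, `Cc1cc(C(=O)O)nn1Cc1cc(Br)ccc1OCc1cc(Cl)cc(Cl)c1`, differs from compound 2 in one place: 3,5-dichlorophenyl in place of 2-methoxyphenyl on a saturated chain carbon bound to an oxygen on an aromatic ring. Within the data shown here, no measured pair shows this change, so the size of the step from compound 2 to compound 3 is expected to be modest and of uncertain direction, a 1.4-fold lower number from compound 2 to compound 3 (0.14 log units; within the scatter). Compound 3 is estimated at 50 nM, within a range of 10 nM to 300 nM.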

Compound 3, inhibition constant: 1120 nM
Compound 3: middle estimate off by 22-fold (1.35 log units), on the low side; the whole stated range lies below it.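

Replacing 2-methoxyphenyl with 3,5-dichlorophenyl gives a 16-fold higher number from compound 2 to compound 3 (1.21 log units; beyond the scatter) in this assay, the first measured sign that inhibition depends on what this position carries. With the rest of the molecule unchanged, the 2-methoxybenzyl group gives clearly stronger inhibition than the 3,5-dichlorobenzyl group. Nothing measured here accounts for the size of this step. Going by these compounds, the methoxy group leaves and two chlorines enter in the same change, so which of these matters remains open. A phenyl ring carrying one chlorine, or a pyridyl ring, in the same place could help to separate them.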